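Acetamido in Place of Cyano: An Unmeasured Step

The compounds below may be only part of what the source reports. "The series", "measured", "known", "first", "only" and "open" are said of these compounds alone.

Two compounds have numbers in an assay on membranes from brain for binding affinity to Adrenergic receptor alpha-1 (Rattus norvegicus); a higher number here means a weaker inhibitor, a lower number a stronger inhibitor. Compound 1 `c1ccc(CC2CCN(Cc3nc4ccccc4[nH]3)CC2)cc1` gives 2800 nM. Compound 2 `N#Cc1ccc2[nH]c(Cc3ccc(Oc4ccccc4)cc3)nc2c1` gives 3400 nM, and the two values lie within the scatter of each other, so neither stands apart. Compound 3 `CC(=O)Nc1ccc2[nH]c(Cc3ccc(Oc4ccccc4)cc3)nc2c1` differs from compound 2 by acetamido in place of cyano on an aromatic carbon. For the measured compounds named here, no measured pair shows a change of this kind, so the size of the step is open; a shift no larger than the scatter of this assay seems most likely, with no clear direction. Compound 3 is therefore expected near 3500 nM, between 1200 nM and 10000 nM. The expected step is a 1.0-fold higher number from compound 2 to compound 3 (0.01 log units; within the scatter).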

Compound 3, half-maximal inhibitory concentration: 20000 nM
For compound 3 the middle estimate is 5.7-fold (0.76 log units) below the measured one, outside the stated range (above it).
By their numbers in this assay, from the lowest: compounds 1 and 2 (each within the scatter of the next); then compound 3.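

Acetamido in place of cyano on this aromatic carbon is not a neutral exchange in this assay: it gives a 5.9-fold higher number from compound 2 to compound 3 (0.77 log units; beyond the scatter), so this position responds to what it carries. The entering group has more heavy atoms and a hydrogen-bond donor that cyano lacks, but the step alone cannot separate these differences. Nothing available accounts for the step.

Still open, as far as these compounds go, is whether a plain amine or a methoxy group on this carbon would follow acetamido or stay close to cyano. Also open, from the compounds shown here alone, is whether a carboxylic acid there would move the number further.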